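Swapping the amide aryl group: chloro to dimethyl

The source may report more compounds than this note shows. Statements on the series, on what has been measured and on what is new or still open speak of the compounds shown alone.

Measured so far in a functional assay on CCRF-CEM cells (Homo sapiens) for cytotoxicity; on this read-out lower numbers stand for stronger inhibition and higher numbers for weaker inhibition:
Compound 1 `O=C(/C=C/C(=O)N1C/C(=C\c2ccc([N+](=O)[O-])cc2)C(=O)/C(=C/c2ccc([N+](=O)[O-])cc2)C1)Nc1ccc(Cl)c(Cl)c1`: 380 nM
Compound 2 `O=C(/C=C/C(=O)N1C/C(=C\c2ccc([N+](=O)[O-])cc2)C(=O)/C(=C/c2ccc([N+](=O)[O-])cc2)C1)Nc1ccc([N+](=O)[O-])cc1`: 410 nM
Compound 3 `O=C(/C=C/C(=O)N1C/C(=C\c2ccc([N+](=O)[O-])cc2)C(=O)/C(=C/c2ccc([N+](=O)[O-])cc2)C1)Nc1ccc(Cl)cc1`: 810 nM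

Going by the values given here, compound 3 has the highest number of the three, though its gap to compound 2 is within the scatter; only the step of a 2.1-fold higher number from compound 1 to compound 3 (0.33 log units; beyond the scatter) is beyond it, and that step was modest. The three compounds share one core and differ only in the aromatic group on the amide-type nitrogen.

Compound 4 `Cc1ccc(NC(=O)/C=C/C(=O)N2C/C(=C\c3ccc([N+](=O)[O-])cc3)C(=O)/C(=C/c3ccc([N+](=O)[O-])cc3)C2)cc1C` continues this series with 3,4-dimethylphenyl in place of 4-chlorophenyl on an amide-type nitrogen. Among the compounds with values here, two measured steps bear on such a change. Removing chloro, in the step of a 2.1-fold higher number from compound 1 to compound 3 (0.33 log units; beyond the scatter), raised the number modestly. Exchanging nitro for chloro, in the step of a 2.0-fold higher number from compound 2 to compound 3 (0.30 log units; within the scatter), stayed within the scatter. Within the data shown here, no measured step involves a methyl group, so the new group is untested here; what the three compounds show is that changes on this aryl ring moved the number only a little. Compound 4 is therefore expected to stay close to compound 3, with a step of a 1.2-fold lower number from compound 3 to compound 4 (0.06 log units; within the scatter) that need not exceed the scatter, and its estimated value in this assay is 700 nM, within a range of 300 nM to 1800 nM.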

Compound 4, half-maximal inhibitory concentration: 700 nM
The estimate for compound 4 equals the measured number at the digits printed; the range from low to high includes it.
By their numbers in this assay, from the lowest: compounds 1, 2, 4 and 3 (each within the scatter of the next, the first and the last beyond it).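

In this assay, placing 3,4-dimethylphenyl on the amide-type nitrogen gives a 1.2-fold lower number from compound 3 to compound 4 (0.06 log units; within the scatter), and the comparisons with the other two aryl groups read a 1.7-fold higher number from compound 2 to compound 4 (0.23 log units; within the scatter) and a 1.8-fold higher number from compound 1 to compound 4 (0.27 log units; within the scatter). Going by these compounds alone, compound 4 is the first of the series whose ring carries only carbon substituents, with no chlorine or nitro group, yet it cannot be told apart from any of the other three compounds, even though compound 1 and compound 3 differ from each other beyond the scatter. Nothing measured here gives a reason for this small response.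

On these data alone, it remains open whether the number would stay in this range with an amine or a carboxylic acid on the aryl ring, or with a longer chain on the ring. All four compounds also share the same core, so they say nothing about changes made there.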